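The compounds below may be only part of what the source reports. "The series", "measured", "known", "first", "only" and "open" are said of these compounds alone.

Of the compounds shown here, two built on the same core have been measured so far. Compound 1 `COc1cccc(-c2nc3cccnc3o2)c1` and compound 2 `O=[N+]([O-])c1ccc(-c2nc3cccnc3o2)cc1` were each tested in a functional assay on the whole organism for inhibition, with Rattus norvegicus as the target, at a dose of 30 mg/kg; on this read-out lower numbers stand for less inhibition and higher numbers for more inhibition at the one dose given (going by the name of the read-out). In this assay compound 1 gives 0%, and compound 2 gives 5%; the two readings lie within the usual scatter of each other, so neither number can be called the higher one. Compound 1 therefore stands at the bottom of these two numbers, with compound 2 close by.

Compound 3 `Cc1cccc(-c2nc3cccnc3o2)c1` has not yet been measured. It differs from compound 1 in one place: methyl in place of methoxy on an aromatic carbon. For the measured compounds named here, with no measured step to guide the expectation, and with both measured readings near zero, the expected step of a number 5 percentage points higher from compound 1 to compound 3 (within the scatter) is small, most likely none beyond the scatter, and could go in either direction. For compound 3 the estimated reading in this assay is 5%, with a range from 0% to 20%.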

Compound 3, a percentage reported as inhibition, in the whole organism at one dose (the size of the read-out at that dose, not a potency): 14%
Compound 3: the middle estimate sits 9 percentage points below what was measured, within the range that was stated.
By their numbers in this assay, from the lowest: compounds 1, 2 and 3 (each within the scatter of the next, the first and the last beyond it).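

In this assay, for the compounds shown here, methyl in place of methoxy on an aromatic carbon gives a number 14 percentage points higher from compound 1 to compound 3 (beyond the scatter) and so provides the first step here that rises beyond the usual scatter between compounds differing in one place. It shows that the reading responds, modestly, to the group held at this place on the six-membered aromatic ring of carbon only, with the rest of the molecule unchanged. Nothing measured here explains why the swap of methoxy for methyl has this effect.

This single swap leaves open whether the reading would climb further with a longer chain such as ethyl, or would respond differently to an amine or a carboxylic acid at the same place. It also leaves open whether the step would persist at doses other than the one tested.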